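The source may hold more compounds than are shown below. What is called first, only, known or untested is meant among the compounds shown, and "the series" means these compounds.

In an assay for binding affinity to Neuropeptide Y receptor type 1 (Homo sapiens), read by radioligand binding (on this read-out lower numbers stand for stronger inhibition and higher numbers for weaker inhibition), compound 1 `Nc1ccc([S+]([O-])c2cc(N)c3ncccc3c2[N+](=O)[O-])cc1` gives 1250 nM. Compound 2 `Nc1ccc(Sc2cc(N)c3ncccc3c2[N+](=O)[O-])cc1` reaches only a limit of this assay, > 10000 nM. Compound 3 `Nc1ccc(S(=O)(=O)c2cc(N)c3ncccc3c2N)cc1` also stops at a limit, > 10000 nM. Compound 3 therefore has no fixed place among the numbers shown; it sits at the limit of > 10000 nM in this assay, at which 2 of the 3 values shown sit, and only compound 1 contributes a measured number. Compound 4 `Nc1ccc(S(=O)(=O)c2cc(N)c3ncccc3c2)cc1` follows from compound 3 by one change, (hydrogen in place of amino on an aromatic carbon), hydrogen in place of amino on an aromatic carbon. Among the measured compounds shown here, no measured pair isolates this change, and compound 3 supplies only a limit as a starting point, so neither a size nor a direction can be read from the data. The author expects compound 4 to stay close to that limit, with an at least 1.2-fold lower number from compound 3 to compound 4 (0.09 log units; that floor lies within the scatter) as the estimated step. The estimate for compound 4 is 8000 nM, expected between 2000 nM and 30000 nM.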

Compound 4, inhibition constant: > 10000 nM
Compound 4: a limit, no number (the forecaster's own chance of this, stated with the estimate: 50%); middle value at least 1.2-fold (0.09 log units) away from the limit.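

Compound 3 and compound 4 both stop at a limit in this assay, so no step can be read between them. The compounds shown leave open what hydrogen in place of amino on an aromatic carbon does to binding, as most values rest at one limit: the limit of > 10000 nM in this assay, at which 3 of the 4 values shown sit.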